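Working notes: from compound 2 to compound 3

The compounds below may be only part of what the source reports. "The series", "measured", "known", "first", "only" and "open" are said of these compounds alone.

Compound 1 `O=C(COCCOc1no[n+]([O-])c1S(=O)(=O)c1ccccc1)NO` at 8150 nM
Compound 2 `CC(C)(COc1no[n+]([O-])c1S(=O)(=O)c1ccccc1)C(=O)NO` at 12500 nM

Going by the values given here, both values come from a functional assay on U-937 cells (Homo sapiens) for inhibition, read by MTT assay, with a stated time of 48 h (on this read-out higher numbers stand for weaker inhibition and lower numbers for stronger inhibition), and compound 2 stands within the scatter of compound 1, the only other compound measured. Compound 3 `CCCC(C)(COc1no[n+]([O-])c1S(=O)(=O)c1ccccc1)C(=O)NO` differs from compound 2 by ethyl in place of hydrogen on a saturated chain carbon, two bonds along the chain from a carbonyl carbon with ethyl in place of hydrogen on a saturated chain carbon, two bonds along the chain from a carbonyl carbon. Among the compounds with values here, the sole measured step (a 1.5-fold higher number from compound 1 to compound 2 (0.19 log units; within the scatter)) lies within the scatter and concerns a different change, so it gives no size for this one. No step beyond the scatter is expected in this assay in either direction. The estimate expects a 1.1-fold lower number from compound 2 to compound 3 (0.06 log units; within the scatter) only. Compound 3 is expected at 11000 nM with 4500 nM to 25000 nM as the range.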

Compound 3, half-maximal inhibitory concentration: 25400 nM
For compound 3 the middle estimate is 2.3-fold (0.36 log units) below the measured one; measured number above the stated range.
By their numbers in this assay, from the lowest: compounds 1 and 2 (each within the scatter of the next); then compound 3.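

In this assay, going by these compounds alone, ethyl in place of hydrogen on a saturated chain carbon, two bonds along the chain from a carbonyl carbon, gives a 2.0-fold higher number from compound 2 to compound 3 (0.31 log units; beyond the scatter) and is the first step beyond the scatter, though a modest one. This position therefore responds to the change, with the number moving toward weaker inhibition. Nothing measured here accounts for the shift.

On these data alone, whether a longer chain at this position moves the number further remains open. So does the outcome with an amine or a carboxylic acid there.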